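Removing one chloro from the core of compound 1

The source may report more compounds than this note shows. Statements on the series, on what has been measured and on what is new or still open speak of the compounds shown alone.

Compound 1 `ClCc1ccc(Cn2cnc3nc(Cl)nc(Cl)c32)cc1` gives 7940 nM in a functional assay on A549 cells (Homo sapiens) for cytotoxicity, read by sulforhodamine B assay, with a stated time of 48 h; on this read-out lower numbers stand for higher toxicity in this test and higher numbers for lower toxicity in this test.
Compound 2 `ClCc1cccc(Cn2cnc3nc(Cl)nc(Cl)c32)c1` gives 55000 nM in this assay.

Of these two numbers, compound 1 has the lower one, and the gap to compound 2 lies beyond the usual scatter. Compound 3 `ClCc1ccc(Cn2cnc3ncnc(Cl)c32)cc1` is not yet measured. It differs from compound 1 by hydrogen in place of chloro on an aromatic carbon. Among the measured compounds shown here, no measured pair shows this change, so the size of its effect is unknown. A modest move toward a higher number in this assay is expected, near or somewhat beyond the scatter, with the step from a 2.0-fold higher number from compound 1 to compound 3 (0.30 log units; within the scatter) as the estimate. Compound 3 is thus expected to give about 16000 nM, in the range 4000 nM to 60000 nM.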

Compound 3, concentration lethal to 50% of the cells: 9330 nM
Beside the measured number, compound 3's estimate is 1.7-fold (0.23 log units) above it; measured number inside the range.
By their numbers in this assay, from the lowest: compounds 1 and 3 (each within the scatter of the next); then compound 2.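

In this assay the swap of chloro for hydrogen on the aromatic carbon between two ring nitrogen atoms gives a 1.2-fold higher number from compound 1 to compound 3 (0.07 log units; within the scatter) and the two compounds cannot be told apart. So this chloro is not needed for the toxicity compound 1 shows in this test. No measurement on hand explains this result. Going by these compounds, whether an amine or a methoxy group on this same carbon would leave the number unmoved stays open. So does the role of the other chloro, which compound 3 keeps.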